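Chain Swap on Compound 2: Amine to Amide

The compounds below may be only part of what the source reports. "The series", "measured", "known", "first", "only" and "open" are said of these compounds alone.

Two compounds have been measured in a functional assay (Oryctolagus cuniculus) for antagonist activity at platelet-activating factor receptor (Cavia porcellus); on this read-out lower numbers stand for stronger inhibition and higher numbers for weaker inhibition:
compound 1, `O=C(c1ccn2c1CSC2c1cccnc1)c1c[nH]c2cc(-c3ccc(F)cc3)ccc12`, gives 75 nM
compound 2, `NCCn1cc(C(=O)c2ccn3c2CSC3c2cccnc2)c2ccc(-c3ccc(F)cc3)cc21`, gives 38 nM

Among the measured compounds shown here, compound 2 shows the lower of the two numbers, yet the one measured step, a 2.0-fold lower number from compound 1 to compound 2 (0.30 log units; within the scatter), stays within the scatter, so the two compounds cannot be told apart on this read-out.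

Compound 3, `CN(C)C(=O)Cn1cc(C(=O)c2ccn3c2CSC3c2cccnc2)c2ccc(-c3ccc(F)cc3)cc21`, differs from compound 2 by dimethylcarbamoyl in place of aminomethyl on a saturated chain carbon bound to an aromatic nitrogen. Cut one bond further out, the same change reads 2-aminoethyl to (dimethylcarbamoyl)methyl. For the measured compounds named here, only one measured step touches this chain at all, and it moved the number within the scatter; no measured pair shows an amine exchanged for an amide. With nothing pointing in either direction, no change beyond the scatter is expected for compound 3 in this assay. Compound 3 is therefore estimated at 50 nM, a step of a 1.3-fold higher number from compound 2 to compound 3 (0.12 log units; within the scatter), with a likely range from 15 nM to 160 nM.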

Compound 3, inhibition constant: 0.7 nM
Compound 3: middle estimate off by 71-fold (1.85 log units), on the high side, outside the stated range (below it).
By their numbers in this assay, from the lowest: compound 3; then compounds 2 and 1 (each within the scatter of the next).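

In this assay, this chain on the aromatic nitrogen proves able to shift the number strongly: dimethylcarbamoyl in place of aminomethyl gives a 54-fold lower number from compound 2 to compound 3 (1.73 log units; beyond the scatter), a step beyond the scatter, whereas the earlier 2-aminoethyl step stayed within it. Measured against hydrogen on the aromatic nitrogen, (dimethylcarbamoyl)methyl gives a 110-fold lower number from compound 1 to compound 3 (2.03 log units; beyond the scatter), so what matters here is which chain is attached, and not merely that one is present. Nothing measured here explains why this chain differs so much from 2-aminoethyl.

As far as these compounds go, it remains open which part of the (dimethylcarbamoyl)methyl group carries the step, since a simple carbamoyl without the two methyl groups, or a carboxylic acid on the same chain, could help separate those parts. A longer chain ending in dimethylcarbamoyl would show whether the distance from the aromatic nitrogen also counts.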